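Extending the Basic Amide Tail on a Shared Sulfonamide Core

The compounds below may be only part of what the source reports. "The series", "measured", "known", "first", "only" and "open" are said of these compounds alone.

Compound 1 `COc1ccc(S(=O)(=O)N(CC(N)=O)c2ccc(N(CC(N)=O)S(=O)(=O)c3ccc(NC(=O)CN4CCCCC4)cc3)c3ccccc23)cc1`: > 100000 nM
Compound 2 `COc1ccc(S(=O)(=O)N(CC(N)=O)c2ccc(N(CC(N)=O)S(=O)(=O)c3ccc(NC(=O)CCN4CCN(C(C)C)CC4)cc3)c3ccccc23)cc1`: > 100000 nM
Compound 3 `CCN1CCN(CCCC(=O)Nc2ccc(S(=O)(=O)N(CC(N)=O)c3ccc(N(CC(N)=O)S(=O)(=O)c4ccc(OC)cc4)c4ccccc34)cc2)CC1`: > 100000 nM

Of the compounds shown here, three built on the same core have been tested in a functional assay on cells (Peritoneal macrophage, Mus musculus) for cytotoxicity, with a stated time of 24 h; on this read-out lower numbers stand for higher toxicity in this test and higher numbers for lower toxicity in this test. Compound 1 gives > 100000 nM, which is a limit of the assay rather than a number. Compound 2 gives > 100000 nM, again a limit. Compound 3 gives > 100000 nM, also a limit. Evidence for this comes from the limit of > 100000 nM in this assay, at which 3 of the 3 values shown sit. As a result, the changes among them leave no readable step: a step that the two limits leave unreadable from compound 1 to compound 2, a step that the two limits leave unreadable from compound 1 to compound 3 and a step that the two limits leave unreadable from compound 2 to compound 3 cannot be sized, and compound 1 cannot be placed above or below its two companions.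

Compound 4 `COc1ccc(S(=O)(=O)N(CC(N)=O)c2ccc(N(CC(N)=O)S(=O)(=O)c3ccc(NC(=O)CCCN4CCN(C(C)C)CC4)cc3)c3ccccc23)cc1` is not yet measured. It differs from compound 1 as follows: 2-(4-isopropylpiperazin-1-yl)ethyl in place of piperidin-1-yl on a saturated chain carbon bound to a carbonyl carbon. This exchange resembles the ones already seen, in that a saturated amine-bearing tail on the amide is replaced by a longer tail carrying a substituted piperazine, and the measured compounds bearing such tails all sit at the limit. The expectation for compound 4 is therefore that it too reaches the limit, with a step that the limit leaves unreadable from compound 1 to compound 4 expected to be no readable step. Compound 4 is estimated at 150000 nM, within a range from 50000 nM to 500000 nM, most likely reported only as a limit.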

Compound 4, half-maximal cytotoxic concentration: > 100000 nM
Compound 4 gave a limit, no number (the forecaster's own chance of this, stated with the estimate: 85%); the middle value lies beyond the limit too.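

Compound 4 gives > 100000 nM, again a limit and not a number. No step from compound 4 to compound 1, compound 2 or compound 3 can be read: the limit of > 100000 nM in this assay, at which 4 of the 4 values shown sit.

The compounds shown leave open whether any of these amide tails separates one compound from another in this assay, and how far beyond the limit each compound lies.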